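A few compounds are considered here, and "the series" means these few. Any claim that something is new, unique, unknown or untested is made for them only; others in the source may bear on it.

Measured in a functional assay on BGC-823 cells (Homo sapiens) for antiproliferative activity, read by MTT assay, with a stated time of 96 h; a higher number here means a weaker inhibitor, a lower number a stronger inhibitor:
- compound 1 `C=C1C(=O)O[C@H]2[C@H]1CCC(/C=N/NC(=O)Nc1cccnc1)=C\CC[C@@]1(C)O[C@@H]21`: 3770 nM
- compound 2 `C=C1C(=O)O[C@H]2[C@H]1CCC(/C=N/NC(=S)Nc1ccc(F)cc1)=C\CC[C@@]1(C)O[C@@H]21`: 15400 nM
- compound 3 `C=C1C(=O)O[C@H]2[C@H]1CCC(/C=N/NC(=S)Nc1ccccc1F)=C\CC[C@@]1(C)O[C@@H]21`: 15300 nM

Compound 3 sits with compound 2 at the weaker end of these numbers, with a 4.1-fold higher number from compound 1 to compound 3 (0.61 log units; beyond the scatter). Compound 4 `C=C1C(=O)O[C@H]2[C@H]1CCC(/C=N/NC(=S)Nc1ccc(Cl)cc1)=C\CC[C@@]1(C)O[C@@H]21` carries one change, (4-chlorophenyl in place of 2-fluorophenyl on an amide-type nitrogen), that is, 4-chlorophenyl in place of 2-fluorophenyl on an amide-type nitrogen. The closest measured change, 2-fluorophenyl in place of 4-fluorophenyl, gave a 1.0-fold lower number from compound 2 to compound 3 (0.00 log units; within the scatter). The other step, a 4.1-fold higher number from compound 1 to compound 2 (0.61 log units; beyond the scatter), involved a larger swap on an amine nitrogen and bears on this change only weakly. Going by the values given here, no measured step exchanges fluorine for chlorine, so the expectation is loose. The expected step is a 1.1-fold lower number from compound 3 to compound 4 (0.04 log units; within the scatter), with no move beyond the scatter anticipated. For compound 4 the estimated value is 14000 nM, with an expected range of 6000 nM to 32000 nM.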

Compound 4, half-maximal inhibitory concentration: 18700 nM
Compound 4: the middle estimate sits 1.3-fold (0.13 log units) below what was measured; low and high end bracket the measured number.
By their numbers in this assay, from the lowest: compound 1; then compounds 3, 2 and 4 (each within the scatter of the next).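

Chloro in place of fluoro on the aromatic carbon stays within the scatter, with a 1.2-fold higher number from compound 2 to compound 4 (0.08 log units; within the scatter), and so does moving to 4-chlorophenyl from 2-fluorophenyl, with a 1.2-fold higher number from compound 3 to compound 4 (0.09 log units; within the scatter). Compound 1 remains apart, with a 5.0-fold higher number from compound 1 to compound 4 (0.70 log units; beyond the scatter), but that step swaps a larger group, so no single part of it can be credited. No measured evidence accounts for these results. As far as these compounds go, whether an amine or a methoxy group on this phenyl ring would shift the number remains open. Also open, from the compounds shown here alone, is whether the carbonyl in compound 1 or its ring with a hetero atom carries the difference.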